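This account rests on a few compounds, and the source may have more. Where it says the series, first, only, none or still open, it means among the compounds named here.

Compound 2 `COc1ccc(C2=C(c3ccc(SC)cc3)CC3CCCN3C2=O)cc1C` gives the lowest of the two numbers in a functional assay on U-251 cells (Homo sapiens) for cytotoxicity (a higher number here means a weaker inhibitor of growth, a lower number a stronger inhibitor of growth), at 90 nM; its nearest neighbour is compound 1 `COc1ccc(C2=C(c3ccc(SC)cc3)CC3CCCN3C2=O)cc1Br`, and compound 1 gives 800 nM. Among the measured compounds shown here, the one measured step, an 8.9-fold lower number from compound 1 to compound 2 (0.95 log units; beyond the scatter), changes only one substituent on the 4-methoxy-3-methylphenyl ring. Compound 3 `CSc1ccc(C2=C(c3ccc(F)c(F)c3)C(=O)N3CCCC3C2)cc1` carries a larger change: 3,4-difluorophenyl in place of 4-methoxy-3-methylphenyl on a double-bonded ring carbon. For the measured compounds named here, no measured step bears directly on a swap of both substituents, so the expectation rests on compound 2 alone, with wide uncertainty leaning toward a weaker inhibitor. The estimated step is a 3.3-fold higher number from compound 2 to compound 3 (0.52 log units; beyond the scatter), giving compound 3 an expected 300 nM within 60 nM to 1500 nM.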

Compound 3, concentration for 50% growth inhibition: 15000 nM
Compound 3: the middle estimate sits 50-fold (1.70 log units) below what was measured; the measured number lies above the stated range.
By their numbers in this assay, from the lowest: compound 2; then compound 1; then compound 3.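

In this assay, the aryl group on this double-bonded ring carbon proves far more sensitive than the bromo-to-methyl change alone suggested: 3,4-difluorophenyl in place of 4-methoxy-3-methylphenyl gives a 170-fold higher number from compound 2 to compound 3 (2.22 log units; beyond the scatter). The same group in place of 3-bromo-4-methoxyphenyl gives a 19-fold higher number from compound 1 to compound 3 (1.27 log units; beyond the scatter), so the loss appears against both methoxy-bearing rings. Nothing available explains this loss. Both ring substituents change at once, leaving the separate contributions of the methoxy group and the fluorines unresolved; a 3-fluoro-4-methoxyphenyl group would help divide them. As far as these compounds go, how an amine or a carboxylic acid on this ring would fare also remains open.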